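Working notes: bromo in place of methoxy

This account rests on a few compounds, and the source may have more. Where it says the series, first, only, none or still open, it means among the compounds named here.

Compound 1 `CCOC(=O)/C=C/c1ccc2c(c1)C(=O)C(=O)N2Cc1ccc(OC)cc1` gives 10 nM in a functional assay on K562 cells (Homo sapiens) for cytotoxicity, read by MTT assay, with a stated time of 48 h; a lower number here means a stronger inhibitor, a higher number a weaker inhibitor; of the two measured compounds it stands highest, the other being compound 2 `COC(=O)/C=C/c1ccc2c(c1)C(=O)C(=O)N2Cc1ccc(OC)cc1`, which gives 3 nM. Within the data shown here, the single measured step, a 3.3-fold lower number from compound 1 to compound 2 (0.52 log units; beyond the scatter), alters only the ester. Compound 3 `CCOC(=O)/C=C/c1ccc2c(c1)C(=O)C(=O)N2Cc1ccc(Br)cc1` differs from compound 1 elsewhere: bromo in place of methoxy on an aromatic carbon. Among the measured compounds shown here, no measured step bears on this part of the molecule, so nothing here sets a size or a direction; the expectation is a step within the scatter, no change at the digits printed from compound 1 to compound 3 (within the scatter). Compound 3 is therefore estimated at 10 nM, with a range from 3 nM to 35 nM.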

Compound 3, half-maximal inhibitory concentration: 30 nM
Estimate against measurement, compound 3: 3.0-fold (0.48 log units) below, and the stated range covers the measured number.
By their numbers in this assay, from the lowest: compound 2; then compound 1; then compound 3.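

The aromatic ring of the 4-methoxybenzyl group responds to substitution: bromo in place of methoxy gives a 3.0-fold higher number from compound 1 to compound 3 (0.48 log units; beyond the scatter) with the core and ester unchanged. Among these compounds, this is the first measured evidence that this position affects the number, and the change raises it. Nothing shown explains this rise.

Methoxy and bromo are the only groups compared at this place, so the effect of an amine, a hydroxyl group or a carboxylic acid there remains open. Also open, on these data alone, is whether the bromo change would give a similar step alongside the methyl ester of compound 2.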